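The compounds below may be only part of what the source reports. "The series", "measured", "known", "first", "only" and "open" are said of these compounds alone.

Going by the values given here, compound 1 `Nc1cc(N)c2nc(-c3ccccc3)c(Oc3ccc(Cl)c(Cl)c3)nc2c1` is one of three compounds measured in a functional assay on KM12 cells (Homo sapiens) for inhibition, read by sulforhodamine B assay, with a stated time of 48 h; on this read-out higher numbers stand for weaker inhibition of growth and lower numbers for stronger inhibition of growth. In this assay compound 1 gives 6310 nM, the lowest of the three numbers. Compound 2 `CCOC(=O)[C@H](CCC(=O)O)NC(=O)c1ccc(Sc2nc3cc(N)cc(N)c3nc2-c2ccccc2)cc1` gives 24000 nM in this assay, and compound 3 `CCOC(=O)[C@H](CCC(=O)O)NC(=O)c1ccc(Oc2nc3cc(N)cc(N)c3nc2-c2ccccc2)cc1` gives 27500 nM. Both of these gaps from compound 1 lie beyond the usual scatter, so compound 1 stands as the most potent of the three measured compounds. Compounds 2 and 3 differ from each other in the atom that links their aryl group to the shared core, one through sulfur and one through oxygen, and their two values lie within the scatter of each other.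

Compound 4 `Nc1cc(N)c2nc(-c3ccccc3)c(Sc3ccc(Cl)c(Cl)c3)nc2c1` has not been measured yet. It differs from compound 1 in one place: (3,4-dichlorophenyl)sulfanyl in place of 3,4-dichlorophenoxy on an aromatic carbon. Among the compounds with values here, no measured pair shows this exact change. What compounds 2 and 3 show is that a sulfur link and an oxygen link gave values within the scatter of each other. On that basis the step of a 1.0-fold lower number from compound 1 to compound 4 (0.00 log units; within the scatter) is expected to be small, in no clear direction, and not beyond the scatter. Compound 4 is therefore estimated at 6300 nM, with a range from 2500 nM to 16000 nM.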

Compound 4, concentration for 50% growth inhibition: 11200 nM
Beside the measured number, compound 4's estimate is 1.8-fold (0.25 log units) below it, within the range that was stated.
By their numbers in this assay, from the lowest: compounds 1 and 4 (each within the scatter of the next); then compounds 2 and 3 (each within the scatter of the next).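

Replacing 3,4-dichlorophenoxy with (3,4-dichlorophenyl)sulfanyl on this aromatic carbon gives a 1.8-fold higher number from compound 1 to compound 4 (0.25 log units; within the scatter) in this assay. This pair reads the exchange of oxygen for sulfur directly on the 3,4-dichlorophenyl compounds, whereas compounds 2 and 3 carry a different aryl group, so the earlier pair could only suggest how this change would behave here. With this small group of compounds, the data give no measured property that could explain the result.

Going by these compounds, whether an amine link at the same carbon would also stay within the scatter of compound 1 remains open. Also open, on these data alone, is how this assay would read with a carboxylic acid in place of the two chlorine atoms.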